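The source may report more compounds than this note shows. Statements on the series, on what has been measured and on what is new or still open speak of the compounds shown alone.

Of the compounds shown here, three sharing one core have been measured. Compound 1 `O=C1CCC(N2C(=O)c3cccc(Nc4ccc(O)cc4)c3C2=O)C(=O)N1` gives 4% in an assay on FRT-Jurkat cells for inhibition of nuclear factor NF-kappa-B complex (Homo sapiens), read by flow cytometry, with a stated time of 24 h, tested at 10 uM; a higher number here means more inhibition at the concentration tested (going by the name of the read-out), a lower number less inhibition; compound 2 `O=C1CCC(N2C(=O)c3cccc(Nc4ccccc4)c3C2=O)C(=O)N1` gives 4% in this assay; compound 3 `C=C(OCC)c1ccc(Nc2cccc3c2C(=O)N(C2CCC(=O)NC2=O)C3=O)cc1` gives 10% in this assay. Compound 3 carries the highest of the three numbers, yet the step of a number 6 percentage points higher from compound 1 to compound 3 (within the scatter) and the step of a number 6 percentage points higher from compound 2 to compound 3 (within the scatter) both lie within the scatter, so the three compounds cannot be told apart on these numbers. Compound 4 `CCc1ccc(Nc2cccc3c2C(=O)N(C2CCC(=O)NC2=O)C3=O)cc1` has not yet been measured. It differs from compound 3 in one place: ethyl in place of 1-ethoxyethenyl on an aromatic carbon. For the measured compounds named here, the steps that bear on this are the earlier exchanges on the same aromatic carbon, namely no change at the digits printed from compound 1 to compound 2 (within the scatter) together with the two steps above, each of which stayed within the scatter. An exchange of one group for another at that spot is therefore expected to produce no step beyond the scatter, and the expected step is a number 4 percentage points lower from compound 3 to compound 4 (within the scatter). Compound 4 is estimated at 6%, in a range from -5% to 17%.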

Compound 4, a percentage reported as inhibition, at one concentration (the size of the read-out at that concentration, not a potency): 17%
Estimate against measurement, compound 4: 11 percentage points below, and the stated range covers the measured number.
By their numbers in this assay, from the lowest: compounds 1, 2, 3 and 4 (each within the scatter of the next, the first and the last beyond it).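

For the compounds shown here, on this aromatic carbon, para to a large group, ethyl is the first group to stand clear of others in this assay: the step is a number 13 percentage points higher from compound 2 to compound 4 (beyond the scatter) when it replaces hydrogen and a number 13 percentage points higher from compound 1 to compound 4 (beyond the scatter) when it replaces hydroxy. Its exchange with 1-ethoxyethenyl gives only a number 7 percentage points higher from compound 3 to compound 4 (within the scatter), so ethyl cannot be separated from that larger group, and the position responds to some exchanges but not clearly to all. Nothing available here accounts for these steps.

The compounds shown carry only hydrogen, hydroxy, 1-ethoxyethenyl and ethyl at this spot, so it remains open whether a propyl chain or an amine there would give a higher or lower number. Each number also comes from a single concentration, so the potency of these compounds remains open too.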